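The compounds below may be only part of what the source reports. "The series", "measured", "known", "first", "only" and "open" are said of these compounds alone.

Measured in a functional assay on HeLa cells (Homo sapiens) for antiproliferative activity, read by MTT assay, with a stated time of 72 h; on this read-out higher numbers stand for weaker inhibition and lower numbers for stronger inhibition:
- compound 1 `CC/C=C/C(=O)Nc1cccc(Oc2nc(Nc3ccn(C)n3)nc3c2CSCC3)c1`: > 50000 nM, a limit of the assay and not a number
- compound 2 `CCC/C=C/C(=O)Nc1cccc(Oc2nc(Nc3ccn(C)n3)nc3c2CSCC3)c1`: 17000 nM
- compound 3 `CC(C)/C=C/C(=O)Nc1cccc(Oc2nc(Nc3ccn(C)n3)nc3c2CSCC3)c1`: 40100 nM

Of the two true numbers in this assay, compound 3 holds the higher, and its nearest neighbour is compound 2, given by a 2.4-fold higher number from compound 2 to compound 3 (0.37 log units; beyond the scatter). Compound 3 cannot be ranked against compound 1, since the floor of an at least 1.2-fold lower number from compound 1 to compound 3 (0.09 log units; that floor lies within the scatter) does not clear the scatter.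

The next compound is compound 4 `C=C(C)C(=O)Nc1cccc(Oc2nc(Nc3ccn(C)n3)nc3c2CSCC3)c1`. It carries 1-methylethenyl in place of 3-methylbut-1-en-1-yl on a carbonyl carbon. For the measured compounds named here, no measured step makes this exact change, so the evidence is indirect. The closest guide is an at least 2.9-fold lower number from compound 1 to compound 2 (0.46 log units; beyond the scatter), where one added methyl on the chain gave a lower number. The branched isomer then gave back part of that gain, as a 2.4-fold higher number from compound 2 to compound 3 (0.37 log units; beyond the scatter) shows. Neither step suggests that a smaller group on the carbonyl carbon would lower the number.

Little change, or a move toward a higher number, therefore seems likely in this assay. The expected step is a 1.1-fold higher number from compound 3 to compound 4 (0.05 log units; within the scatter), and it may not clear the scatter. The assay may well report only a limit for this compound. Compound 4 is estimated at 45000 nM, with an expected range of 15000 nM to 100000 nM.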

Compound 4, half-maximal inhibitory concentration: > 50000 nM
Compound 4 was reported as a limit; the forecaster's own chance of this, stated with the estimate: 45%; at least 1.1-fold (0.04 log units) between middle value and limit.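

In this assay compound 4, with 1-methylethenyl in place of the longer chains on the carbonyl carbon, gives > 50000 nM, which is a limit of the assay and not a number, and it shares that limit with one earlier compound: the limit of > 50000 nM in this assay, at which 2 of the 4 values shown sit.

Against the unbranched chain of compound 2, the change to 1-methylethenyl can be read as an at least 2.9-fold higher number from compound 2 to compound 4 (0.46 log units; beyond the scatter), so the small group on the carbonyl carbon gives up what pent-1-en-1-yl had gained, and this extends the earlier contrast between compound 1 and compound 2 to a chain of a different shape. Against the branched chain the result is only an at least 1.2-fold higher number from compound 3 to compound 4 (0.09 log units; that floor lies within the scatter), so 3-methylbut-1-en-1-yl and 1-methylethenyl are not told apart at this position, while the step between compound 1 and compound 4 runs between two limits and cannot be read.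

Among these four compounds, only compound 2 stands clearly apart, at 17000 nM. The limits leave open how far compound 1 and compound 4 lie from it. From the compounds shown here alone, whether a longer chain, or an amine at the end of the chain, on the same carbonyl carbon would carry the number lower also remains open.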